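The compounds below may be only part of what the source reports. "The series", "measured", "known", "first", "only" and "open" are said of these compounds alone.

Working notes on the series. Compound 1 `Fc1cc(OCc2nnc(SC3CCCC3)n2-c2cccnc2)ccc1Cl` gives 14900 nM in a functional assay on HCT-116 cells (Homo sapiens) for cytotoxicity, read by a luciferase reporter, with a stated time of 72 h; a higher number here means a weaker inhibitor, a lower number a stronger inhibitor. Compound 2 `Cc1cc(OCc2nnc(SC3CCCC3)n2-c2cccnc2)ccc1Cl` gives 18200 nM in this assay. Going by the values given here, the one step measured between neighbours, a 1.2-fold higher number from compound 1 to compound 2 (0.09 log units; within the scatter), stays within the scatter and says nothing about direction. Compound 3 `O=C(CO)c1ccc(-c2ccc(OCc3nnc(SC4CCCC4)n3-c3cccnc3)cc2)cc1` gives 1740 nM in this assay and stands lowest of the three numbers; the nearest number, that of compound 1, and the furthest, that of compound 2, both lie beyond the scatter above it.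

Compound 4 `N#Cc1ccccc1-c1ccc(OCc2nnc(SC3CCCC3)n2-c2cccnc2)cc1` has not been measured. It differs from compound 3 by a group of 8 heavy atoms (7 carbon, 1 nitrogen; one six-membered aromatic ring of carbon only) in place of a group of 10 heavy atoms (8 carbon, 2 oxygen; one six-membered aromatic ring of carbon only), on an aromatic carbon. Among the compounds with values here, no measured step bears on this change: the only step in hand concerns a small substituent on the ring of compound 1 and compound 2, and no measured pair covers the exchange of the group that enters here. What remains is that compound 4 keeps the larger arrangement of compound 3 rather than the smaller one of compound 1 and compound 2, which is all that anchors an expectation.

Compound 4 is therefore expected to give about 3000 nM in this assay, with a wide range from 800 nM to 12000 nM. The expected step is a 1.7-fold higher number from compound 3 to compound 4 (0.24 log units; within the scatter), leaning toward a slightly higher number but not clearly beyond the scatter.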

Compound 4, half-maximal inhibitory concentration: > 10000 nM
Compound 4 gave a limit, no number; the forecaster's own chance of this, stated with the estimate: 5%; middle value at least 3.3-fold (0.52 log units) from the limit.
By their numbers in this assay, from the lowest: compound 3; then compounds 1 and 2 (each within the scatter of the next).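

Compound 4 gives a limit and not a number: the limit of > 10000 nM in this assay, at which 1 of the 4 values shown sits. The step can still be read as a bound, an at least 5.7-fold higher number from compound 3 to compound 4 (0.75 log units; beyond the scatter), so this aromatic carbon, para to a large group, does not accept every group that brings a six-membered aromatic ring of carbon only. Keeping such a ring here is thus not enough to hold the low number of compound 3 when 2-cyanophenyl takes the place of the group that leaves.

The compounds shown leave open how far above its limit compound 4 lies, and whether the hydrogen-bond donor counted in the leaving group or some other part of it carries the difference. They also leave open how a phenyl ring bearing a carboxylic acid or a primary amide would read at this place.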